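This account rests on a few compounds, and the source may have more. Where it says the series, first, only, none or still open, it means among the compounds named here.

Measured compounds in a functional assay on MDA-MB-231 cells (Homo sapiens) for cytotoxicity, read by MTT assay, with a stated time of 72 h; on this read-out higher numbers stand for weaker inhibition and lower numbers for stronger inhibition:
compound 1 `COc1cc2c(Oc3ccc(NC(=O)c4nn(-c5ccc([N+](=O)[O-])cc5)c(=O)c5ccccc45)cc3F)ccnc2cc1OCCCN1CCCCC1` gives 2620 nM
compound 2 `COc1cc2c(Oc3ccc(NC(=O)c4nn(-c5ccccc5)c(=O)c5ccccc45)cc3F)ccnc2cc1OCCCN1CCC(C)CC1` gives 1480 nM
compound 3 `COc1cc2c(Oc3ccc(NC(=O)c4nn(-c5ccc(F)cc5)c(=O)c5ccccc45)cc3F)ccnc2cc1OCCCN1CCC(C)CC1` gives 660 nM

Compound 3 stands at the lowest of the three numbers in this assay; compound 2 sits nearest to it and compound 1 furthest, both beyond the scatter. Within the data shown here, the one single-point step available is a 2.2-fold lower number from compound 2 to compound 3 (0.35 log units; beyond the scatter), where a fluoro replaces a hydrogen on the aromatic carbon of the pendant phenyl ring.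

Compound 4 `COc1cc2c(Oc3ccc(NC(=O)c4nn(-c5ccc([N+](=O)[O-])cc5)c(=O)c5ccccc45)cc3F)ccnc2cc1OCCCN1CCC(C)CC1` differs from compound 3 in one place: nitro in place of fluoro on an aromatic carbon, on an aromatic carbon of a six-membered aromatic ring of carbon only, para to a large group; read one bond further out, 4-fluorophenyl becomes 4-nitrophenyl. Among the measured compounds shown here, no measured step covers fluoro to nitro directly. Compound 1 carries the same 4-nitrophenyl, but it also carries a different amine at the chain end, so its value only shows that a nitro-bearing member of the series gives the highest number of the three.

On that basis the expectation for this assay is a modest rise in number, estimated as a 2.3-fold higher number from compound 3 to compound 4 (0.36 log units; beyond the scatter), though the direction rests on a single indirect comparison. Compound 4 is accordingly expected to give about 1500 nM, within a range of 600 nM to 4000 nM.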

Compound 4, half-maximal inhibitory concentration: 4010 nM
Estimate against measurement, compound 4: 2.7-fold (0.43 log units) below, and the stated range ends below it.
By their numbers in this assay, from the lowest: compound 3; then compounds 2, 1 and 4 (each within the scatter of the next, the first and the last beyond it).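

With the methyl-bearing ring at the chain end held constant, this assay now gives a direct reading of this aromatic carbon, para to a large group: fluoro to nitro is a 6.1-fold higher number from compound 3 to compound 4 (0.78 log units; beyond the scatter) and hydrogen to nitro is a 2.7-fold higher number from compound 2 to compound 4 (0.43 log units; beyond the scatter) on the same compounds. Set beside a 2.2-fold lower number from compound 2 to compound 3 (0.35 log units; beyond the scatter) for hydrogen to fluoro, this shows that the position responds in both directions among compounds 2, 3 and 4, and that the 4-nitrophenyl member gives a higher number than the unsubstituted phenyl, not merely a smaller gain than 4-fluorophenyl. With nitro in place, the methyl on the saturated ring gives a 1.5-fold higher number from compound 1 to compound 4 (0.18 log units; within the scatter) and so shows no change that can be told from the scatter, which means the earlier nitro-bearing compound 1 is now tied to this position by a matched pair. No measurement in hand explains why fluoro and nitro separate in this way.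

Going by these compounds, whether the higher number belongs to nitro alone or extends to other groups at this carbon, such as nitrile, trifluoromethyl or an amine, stays open. Also open, on these data alone, is whether the fluoro step holds when the saturated ring lacks its methyl, or with a different amine at the chain end.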